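The source may hold more compounds than are shown below. What is called first, only, known or untested is meant among the compounds shown, and "the series" means these compounds.

Compound 1, `O=C(CCC(=O)OCCCCCCSc1ccc([N+](=O)[O-])c2nonc12)Nc1ccccc1F`: 840 nM
Compound 2, `COc1ccc(NC(=O)CCC(=O)OCCCCCCSc2ccc([N+](=O)[O-])c3nonc23)cc1`: 1590 nM

In an ADME assay on HUVEC cells (Homo sapiens) for cytotoxicity, read by MTT assay, with a stated time of 72 h (on this read-out lower numbers stand for stronger inhibition and higher numbers for weaker inhibition), compound 2 gives 1590 nM. Going by the values given here, this is the highest of the two numbers measured so far, yet the nearest value, that of compound 1, lies close: the step of a 1.9-fold higher number from compound 1 to compound 2 (0.28 log units; within the scatter) stays within the scatter, so the two compounds cannot be told apart on this read-out. That step exchanged one aryl group for another on the amide nitrogen.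

Compound 3, `COc1ccc(NC(=O)CCC(=O)OCCCCCCSc2ccc([N+](=O)[O-])c3nonc23)cc1OC`, keeps the core of compound 2 and differs from it by a single addition: methoxy in place of hydrogen on an aromatic carbon. Among the compounds with values here, no measured step adds a group to a ring that is already present; the only step available changes the whole ring, and it was small. Within the data shown here, with the closest precedent lying within the scatter, nothing in the data points to a large move in either direction for this assay. The expectation for compound 3 is therefore a value near that of compound 2, with a step of a 1.1-fold higher number from compound 2 to compound 3 (0.05 log units; within the scatter). Compound 3 is estimated at 1800 nM, most likely between 800 nM and 4000 nM.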

Compound 3, half-maximal inhibitory concentration: 870 nM
Compound 3: the middle estimate sits 2.1-fold (0.32 log units) above what was measured; measured number inside the range.
By their numbers in this assay, from the lowest: compounds 1, 3 and 2 (each within the scatter of the next).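

Compound 3 shows what the earlier pair could not: the effect of adding a group to a ring that already carries one, here a methoxy on an aromatic carbon, ortho to a methoxy group and meta to a large group. In this assay this addition gives a 1.8-fold lower number from compound 2 to compound 3 (0.26 log units; within the scatter), so at this position the extra methoxy produces no difference that can be separated from the usual spread of repeated measurements. Comparing whole rings, 3,4-dimethoxyphenyl in place of 2-fluorophenyl on the amide-type nitrogen gives a 1.0-fold higher number from compound 1 to compound 3 (0.02 log units; within the scatter), which means that all three compounds remain indistinguishable on this read-out, and no measurement is available to offer an explanation for the numbers.

The compounds shown leave open whether any change on this ring can produce a step beyond the scatter, for example an amine or a carboxylic acid on the same aromatic carbon. They also leave open whether a longer chain in place of the one shared by all three compounds would matter more than the ring does.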